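The compounds below may be only part of what the source reports. "The series", "measured", "known", "first", "only" and "open" are said of these compounds alone.

Measured in a functional assay on MCF7 cells (Homo sapiens) for antiproliferative activity, read by CCK-8 assay, with a stated time of 48 h; on this read-out higher numbers stand for weaker inhibition and lower numbers for stronger inhibition:
- compound 1 `O=C(/C=C/CNCCOc1ccc(Oc2c(-c3ccc(F)cc3)sc3cc(O)ccc23)cc1)N1CCCC1`: 7610 nM.
- compound 2 `O=C(/C=C/CN1CC(Oc2ccc(Oc3c(-c4ccc(F)cc4)sc4cc(O)ccc34)cc2)C1)N1CCCC1`: 8450 nM.
- compound 3 `O=C(/C=C/CN1CC(Oc2ccc(Oc3c(-c4ccc(F)cc4)sc4cc(O)ccc34)cc2)C1)N1CCC1`: > 25000 nM, a limit of the assay and not a number.

Going by the values given here, compound 1 lies within the scatter of compound 2, the only other compound with a numeric value. Compound 4 `O=C(/C=C/CNCCOc1ccc(Oc2c(-c3ccc(F)cc3)sc3cc(O)ccc23)cc1)N1CCCCC1` is the next case, with the change (piperidin-1-yl in place of pyrrolidin-1-yl on a carbonyl carbon), that is, piperidin-1-yl in place of pyrrolidin-1-yl on a carbonyl carbon.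

Among the compounds with values here, one measured step bears on it: an at least 2.9-fold higher number from compound 2 to compound 3 (0.47 log units; beyond the scatter), beyond the scatter, with azetidin-1-yl in place of pyrrolidin-1-yl at the same kind of place. That step ends in a limit, does not start from compound 1, and goes to a smaller ring, whereas the change here goes to a larger one. It therefore gives no reliable size for the change at hand, and no step beyond the scatter is expected in this assay. The expected 1.1-fold lower number from compound 1 to compound 4 (0.04 log units; within the scatter) stays within the scatter, though with wide uncertainty. For compound 4 the estimated value is 7000 nM, with an expected range of 3000 nM to 18000 nM.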

Compound 4, half-maximal inhibitory concentration: 16400 nM
Beside the measured number, compound 4's estimate is 2.3-fold (0.37 log units) below it, and the stated range covers the measured number.
By their numbers in this assay, from the lowest: compounds 1, 2 and 4 (each within the scatter of the next, the first and the last beyond it). At a limit, above all of these: compound 3.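

In this assay, the place on the carbonyl carbon now gives a step that can be read as a number, and it goes to the larger ring: a 2.2-fold higher number from compound 1 to compound 4 (0.33 log units; beyond the scatter), with piperidin-1-yl in place of pyrrolidin-1-yl. The only earlier step at this kind of place went to the smaller azetidin-1-yl ring, started from compound 2 and ended in a limit, so on the compounds shown, both ring sizes tried away from pyrrolidin-1-yl go to a higher number. Nothing shown gives a cause for this step.

Open, as far as these compounds go, is whether piperidin-1-yl gives a step of similar size on the chain of compound 2. Also open, from the compounds shown here alone, is how a morpholin-4-yl ring or an open-chain dimethylamino group would read on this carbonyl carbon.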